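A few compounds are considered here, and "the series" means these few. Any claim that something is new, unique, unknown or untested is made for them only; others in the source may bear on it.

Measured compounds in a functional assay on HL-60 cells (Homo sapiens) for antiproliferative activity, read by MTT assay, with a stated time of 72 h; a higher number here means a weaker inhibitor, a lower number a stronger inhibitor: compound 1 `NC1=NC2(CCOCC2)N(OCCCOc2ccccc2)C(N)=N1` gives 2460 nM; compound 2 `COc1ccc(OCCCON2C(N)=NC(N)=NC23CCOCC3)cc1` gives 1670 nM; compound 3 `Cc1cc(C)cc(OCCCON2C(N)=NC(N)=NC23CCOCC3)c1` gives 720 nM.

Compound 3 has the lowest of the three numbers, and both steps toward it, a 3.4-fold lower number from compound 1 to compound 3 (0.53 log units; beyond the scatter) and a 2.3-fold lower number from compound 2 to compound 3 (0.37 log units; beyond the scatter), lie beyond the scatter, whereas a 1.5-fold lower number from compound 1 to compound 2 (0.17 log units; within the scatter) stays within it. Compound 4 `Cc1ccc(OCCCON2C(N)=NC(N)=NC23CCOCC3)cc1` differs from compound 3 by 4-methylphenyl in place of 3,5-dimethylphenyl on an oxygen on a saturated carbon. The relevant comparison is the unsubstituted phenyl of compound 1, which sits well above compound 3 in this assay; compound 4 lies structurally between those two, so a modest rise in the number is expected, a 1.7-fold higher number from compound 3 to compound 4 (0.22 log units; within the scatter), smaller than the earlier step. Compound 4 is estimated at 1200 nM, with a likely range from 600 nM to 2500 nM.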

Compound 4, half-maximal inhibitory concentration: 2580 nM
Beside the measured number, compound 4's estimate is 2.2-fold (0.33 log units) below it, outside the stated range (above it).
By their numbers in this assay, from the lowest: compound 3; then compounds 2, 1 and 4 (each within the scatter of the next).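

In this assay, 4-methylphenyl in place of 3,5-dimethylphenyl on this oxygen gives a 3.6-fold higher number from compound 3 to compound 4 (0.55 log units; beyond the scatter) and removes the advantage seen so far. A single methyl does not reproduce that advantage: methyl in place of hydrogen gives a 1.0-fold higher number from compound 1 to compound 4 (0.02 log units; within the scatter) and methyl in place of methoxy gives a 1.5-fold higher number from compound 2 to compound 4 (0.19 log units; within the scatter) as well. Among these four compounds, only the 3,5-dimethylphenyl stands clearly apart, and only from the other three aryl groups shown. As far as these compounds go, whether 3,5-dichlorophenyl or naphthyl on the same oxygen would match it remains open. Nothing measured here accounts for the step.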